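Pyrrolidine for morpholine on the thiosemicarbazide end

The source may hold more compounds than are shown below. What is called first, only, known or untested is meant among the compounds shown, and "the series" means these compounds.

Three compounds of the series have been run in a functional assay on A-431 cells (Homo sapiens) for cytotoxicity, read by MTT assay, with a stated time of 72 h, tested at 30 uM; a higher number here means more inhibition of growth at the concentration tested, a lower number less inhibition of growth. Compound 1 `N/C(=N\NC(=S)N1CCOCC1)c1ccccn1` gives 78.8%. Compound 2 `Cc1ccnc(/C(N)=N/NC(=S)N2CCOCC2)c1` gives 74.6%, and compound 3 `N/C(=N\NC(=S)N1CCN(c2ccccn2)CC1)c1ccccn1` gives 74.9%. Among the measured compounds shown here, the one single-point step among them, a number 4.2 percentage points lower from compound 1 to compound 2 (within the scatter), shows that the methyl on the aromatic carbon does not move the read-out beyond the scatter. Compound 2 has the smallest of the three numbers, but its distance to compound 3 and to compound 1 is within the scatter in both cases, so the three are indistinguishable on this evidence.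

The next compound, compound 4 `Cc1ccnc(/C(N)=N/NC(=S)N2CCCC2)c1`, differs from compound 2 by pyrrolidin-1-yl in place of morpholin-4-yl on a thiocarbonyl carbon. For the measured compounds named here, no measured step in the set changes this part of the molecule; compound 1 and compound 3 carry different groups on the thiocarbonyl carbon and sit within the scatter of each other, but that pair is not a single-point comparison. With nothing in the data pointing to a change in either direction, the expectation for this assay is no step beyond the scatter, expressed as a number 1.6 percentage points lower from compound 2 to compound 4 (within the scatter). Compound 4 is therefore estimated at 73%, with a range from 60% to 85%.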

Compound 4, percent growth inhibition at one concentration: 84.2%
Compound 4: middle estimate off by 11.2 percentage points, on the low side, and the stated range covers the measured number.
By their numbers in this assay, from the lowest: compounds 2, 3, 1 and 4 (each within the scatter of the next).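

In this assay, among the compounds shown here, the exchange of morpholin-4-yl for pyrrolidin-1-yl on a thiocarbonyl carbon gives the first single-point reading at this position: a number 9.6 percentage points higher from compound 2 to compound 4 (within the scatter). On this evidence, the position accepts a five-membered non-aromatic ring with 1 hetero atom in place of a six-membered one with 2, and the loss of the ring oxygen with its hydrogen-bond acceptor, without a step beyond the scatter; this holds for one pair only, on the methyl-carrying core of compound 2. No measurement on hand bears on this step, and no reason can be attached to it.

As far as these compounds go, the same exchange on the core of compound 1, which lacks the methyl, remains unread, so it is open whether the step would come out alike there. Also open, from the compounds shown here alone, is how piperidin-1-yl, an open-chain dimethylamino group or an unsubstituted amino group on the thiocarbonyl carbon would read in this assay, and whether any group at this position would give a step beyond the scatter.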